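Swapping sec-butyl for trifluoroethyl on compound 3

The compounds below may be only part of what the source reports. "The series", "measured", "known", "first", "only" and "open" are said of these compounds alone.

Measured in a physicochemical assay for lipophilicity, using the shake flask method; on this read-out higher numbers stand for higher lipophilicity and lower numbers for lower lipophilicity:
Compound 1 `CCC(C)C(=O)N1CCC(NC(=O)Nc2ccc(C(C)C)cc2)CC1`: 4.21
Compound 2 `CCC(C)C(=O)N1CCC(NC(=O)Nc2ccc(C(C)(C)C)cc2)CC1`: 5.12
Compound 3 `CCC(C)C(=O)N1CCC(NC(=O)Nc2ccc(C(F)(C(F)(F)F)C(F)(F)F)cc2)CC1`: 4.96

Compound 3 stands at the upper end of this small set. The data show a number 0.16 log units lower from compound 2 to compound 3 (within the scatter), so those two cannot be told apart, and a number 0.75 log units higher from compound 1 to compound 3 (beyond the scatter).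

Compound 4 `O=C(Nc1ccc(C(F)(C(F)(F)F)C(F)(F)F)cc1)NC1CCN(C(=O)CC(F)(F)F)CC1` carries 2,2,2-trifluoroethyl in place of sec-butyl on a carbonyl carbon. Going by the values given here, no measured step changes that place, so the evidence is only indirect. All three steps lie elsewhere on the structure. The two that bring in a fluorinated group are a number 0.75 log units higher from compound 1 to compound 3 (beyond the scatter) and a number 0.16 log units lower from compound 2 to compound 3 (within the scatter), and the third is a number 0.91 log units higher from compound 1 to compound 2 (beyond the scatter). These steps give a guide to size but do not settle the direction, so a modest fall is expected, with wide uncertainty. The expected change is a number 0.56 log units lower from compound 3 to compound 4 (beyond the scatter). Compound 4 is estimated at 4.4, with an expected range from 3.8 to 5.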

Compound 4, partition coefficient: 4.89
Compound 4: the middle estimate sits 0.49 log units below what was measured; the range from low to high includes it.
By their numbers in this assay, from the lowest: compound 1; then compounds 4, 3 and 2 (each within the scatter of the next).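

Going by these compounds alone, at this position, on a carbonyl carbon whose other neighbour is the amide-type nitrogen in a ring, the earlier compounds all carried sec-butyl and so gave no reading of any change there. In this assay, replacing sec-butyl with 2,2,2-trifluoroethyl gives a number 0.07 log units lower from compound 3 to compound 4 (within the scatter) and so the two compounds cannot be told apart on this read-out. Nothing measured here offers an explanation for this result.

This single pair, which carries the 1,2,2,2-tetrafluoro-1-(trifluoromethyl)ethyl group on the aromatic carbon, leaves open whether the same swap would read alike with isopropyl or tert-butyl in that place. Also open is what a longer chain, an amine or a carboxylic acid on this carbonyl carbon would give, so the compounds shown define no trend for this position.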